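The source may hold more compounds than are shown below. What is called first, only, known or untested is meant among the compounds shown, and "the series" means these compounds.

Compound 1 `C[C@@H]1CN(c2ccc(-c3n[nH]c4cnc(N5[C@H](C)CCC[C@@H]5C)nc34)cn2)CCN1` gives 2.5 nM in an assay on Sf9 cells for inhibition of activin receptor type-1 (Homo sapiens), read by HTRF, with a stated time of 3 h, in the presence of a further agent that is not named here; on this read-out higher numbers stand for weaker inhibition and lower numbers for stronger inhibition. Compound 2 `COC(=O)N1C[C@@H](C)N(c2ncc3[nH]nc(-c4ccc(N5CCN(C)CC5)c(F)c4)c3n2)[C@@H](C)C1` gives 1.3 nM. Compound 3 `C[C@@H]1CN(c2ccc(-c3n[nH]c4cnc(N5[C@H](C)CNC[C@@H]5C)nc34)cn2)CCN1` gives 793 nM.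

Compound 2 has the lowest number of the three; compound 1 lies within the scatter of it, while compound 3 sits far higher, as seen in the step of a 320-fold higher number from compound 1 to compound 3 (2.50 log units; beyond the scatter), which swaps 2,6-dimethylpiperazin-1-yl for 2,6-dimethylpiperidin-1-yl on an aromatic carbon. Compound 4 `COC(=O)N1C[C@@H](C)N(c2ncc3[nH]nc(-c4ccc(N5CCN(C)CC5)cc4)c3n2)[C@@H](C)C1` differs from compound 2 by hydrogen in place of fluoro on an aromatic carbon, ortho to a 4-methylpiperazin-1-yl group. Within the data shown here, no measured step touches this fluoro position, so nothing bears on it directly. The step of a 1.2-fold higher number from compound 2 to compound 4 (0.09 log units; within the scatter) is expected to stay within the scatter. Compound 4 is therefore estimated at 1.6 nM, between 0.5 nM and 5 nM, in this assay.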

Compound 4, half-maximal inhibitory concentration: 0.98 nM
The estimate for compound 4 lay 1.6-fold (0.21 log units) above the measured number; the range from low to high includes it.
By their numbers in this assay, from the lowest: compounds 4, 2 and 1 (each within the scatter of the next, the first and the last beyond it); then compound 3.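

In this assay, among these compounds, the step of a 1.3-fold lower number from compound 2 to compound 4 (0.12 log units; within the scatter) is the first reading at this position, and it shows that hydrogen can take the place of fluoro, ortho to a 4-methylpiperazin-1-yl group, without a difference beyond the scatter. In this pair, therefore, the fluoro group is not needed for a low number. Nothing at hand explains why the two numbers stay so close.

Only fluoro and hydrogen are shown on this carbon, so the outcome with chloro, methoxy or an amine there remains open. As far as these compounds go, how compound 2 and compound 4 compare outside this assay also remains open.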